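Growing the Branched Chain of Compound 3

The source may report more compounds than this note shows. Statements on the series, on what has been measured and on what is new or still open speak of the compounds shown alone.

Measured so far:
compound 1 `Cc1ccccc1Cc1cnc(CCc2ccc(-c3ccccc3C(=O)O)cc2)[nH]1` gives 127 nM
compound 2 `O=C(O)c1ccccc1-c1ccc(CCc2ncc(Cc3ccccc3Cl)[nH]2)cc1` gives 292 nM
compound 3 `CC(C)(C)Cc1cnc(CCc2ccc(-c3ccccc3C(=O)O)cc2)[nH]1` gives 106 nM

These three compounds share one core and differ only in the group on a saturated chain carbon bound to an aromatic carbon. In an in vitro functional assay on cells for agonist activity at Bombesin receptor subtype-3 (Homo sapiens), read by luminescence and calcium flux (on this read-out higher numbers stand for an effect only at larger amounts of compound and lower numbers for an effect already at smaller amounts), compound 3 and compound 1 lie within the scatter of each other, as the step of a 1.2-fold lower number from compound 1 to compound 3 (0.08 log units; within the scatter) shows, while compound 2 sits apart from both, see a 2.3-fold higher number from compound 1 to compound 2 (0.36 log units; beyond the scatter) and a 2.8-fold lower number from compound 2 to compound 3 (0.44 log units; beyond the scatter).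

Compound 4 `CCC(C)(CC)Cc1cnc(CCc2ccc(-c3ccccc3C(=O)O)cc2)[nH]1` carries a larger branched chain: 1-ethyl-1-methylpropyl in place of tert-butyl on a saturated chain carbon bound to an aromatic carbon. For the measured compounds named here, no measured step swaps one branched chain for another, so the known steps bear on it only loosely. They show that the group at this position can change from an aromatic ring to tert-butyl with no step beyond the scatter (a 1.2-fold lower number from compound 1 to compound 3 (0.08 log units; within the scatter)), and that a modest step is the largest seen (a 2.8-fold lower number from compound 2 to compound 3 (0.44 log units; beyond the scatter)). A step within the scatter is therefore expected in this assay for compound 4, in either direction.

Compound 4 is estimated to give 100 nM, with a range from 45 nM to 220 nM. The expected step is a 1.1-fold lower number from compound 3 to compound 4 (0.03 log units; within the scatter).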

Compound 4, half-maximal effective concentration: 76 nM
Compound 4: middle estimate off by 1.3-fold (0.12 log units), on the high side, within the range that was stated.
By their numbers in this assay, from the lowest: compounds 4, 3 and 1 (each within the scatter of the next); then compound 2.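

For the compounds shown here, compound 4 gives the first measured swap of one branched chain for a larger one at this position, and in this assay the swap stays small: a 1.4-fold lower number from compound 3 to compound 4 (0.14 log units; within the scatter). The larger chain also remains within the scatter of the 2-methylphenyl group, with a 1.7-fold lower number from compound 1 to compound 4 (0.22 log units; within the scatter), while its step from the 2-chlorophenyl group lies beyond the scatter, with a 3.8-fold lower number from compound 2 to compound 4 (0.58 log units; beyond the scatter). No measurement at hand gives a reason for these steps.

The groups shown at this position are only branched hydrocarbon chains and phenyl rings carrying a methyl or chloro group, so a chain bearing an amine or a hydroxyl group remains an open case. Also open, as far as these compounds go, is how a cyclohexyl ring or a still longer branched chain would fare here.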